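A few compounds are considered here, and "the series" means these few. Any claim that something is new, unique, unknown or untested is made for them only; others in the source may bear on it.

Of the compounds shown here, three sharing one core have been tested in a functional assay on K562 cells (Homo sapiens) for inhibition, read by sulforhodamine B assay, with a stated time of 48 h, tested at 10 uM (on this read-out higher numbers stand for a weaker effect at the one concentration tested and lower numbers for a stronger effect), and one more awaits a number.

Compound 1, `O=C(Nc1cccc(-n2cc(-c3ccncc3)c(-c3cc(O)cc(Cl)c3)n2)c1)Nc1ccc(Cl)c(Cl)c1`, gives 1.06% in this assay. Compound 2, `COc1cc(Cl)cc(-c2nn(-c3cccc(NC(=O)Nc4ccc(Cl)c(Cl)c4)c3)cc2-c2ccncc2)c1`, differs from it by one change, (methyl in place of hydrogen on an oxygen on an aromatic ring), and gives 10%. The step of a number 8.9 percentage points higher from compound 1 to compound 2 (within the scatter) is small enough that the two values cannot be told apart.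

Compound 3, `O=C(Nc1cccc(-n2cc(-c3ccncc3)c(-c3cc(O)cc(Cl)c3)n2)c1)c1cc(C(F)(F)F)cc(C(F)(F)F)c1`, carries a different core; how it differs from compound 1 is not broken down here. In this assay compound 3 gives 20.4%, which sets it apart from both compound 1 and compound 2.

Compound 4, `COc1cc(Cl)cc(-c2nn(-c3cccc(NC(=O)c4cc(C(F)(F)F)cc(C(F)(F)F)c4)c3)cc2-c2ccncc2)c1`, is related to compound 3 by the same change that links compound 1 to compound 2: methyl in place of hydrogen on an oxygen on an aromatic ring. Since that change on the core of compound 1 produced only a number 8.9 percentage points higher from compound 1 to compound 2 (within the scatter), a step of similar size is expected for compound 4, namely a number 6.6 percentage points higher from compound 3 to compound 4 (within the scatter), with some allowance for the different core. On that basis compound 4 is estimated to give 27% in this assay, with a plausible range from 10% to 50%.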

Compound 4, a percentage reported as activity, at one concentration (the size of the read-out at that concentration, not a potency): 38%
For compound 4 the middle estimate is 11 percentage points below the measured one; the measured number falls inside the stated range.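

Capping the hydroxy group as methoxy on the core of compound 3, which turns 3-chloro-5-hydroxyphenyl into 3-chloro-5-methoxyphenyl, gives in this assay a number 17.6 percentage points higher from compound 3 to compound 4 (beyond the scatter). This step is beyond the usual scatter while the earlier one is not, yet the two steps themselves cannot be told apart, so the change carries over from one core to the other with a comparable effect: the same change on two cores in this assay, a number 8.9 percentage points higher (within the scatter) from compound 1 to compound 2 and a number 17.6 percentage points higher (beyond the scatter) from compound 3 to compound 4, 8.7 percentage points apart, within the scatter of two such steps. Two pairs are a narrow base, however: they do not show that the step would keep its size on any other core, and they give no reason for its size.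

The compounds shown have only hydroxy or methoxy at this place, so it remains open what an amine, a carboxylic acid or a longer chain such as ethoxy would do there. On these data alone, these readings show only the size of the effect at the single concentration tested, so how the effect of these four compounds would change at other concentrations remains open.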